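The compounds below may be only part of what the source reports. "The series", "measured", "known", "first", "only" and "open" are said of these compounds alone.

Series notes on an ADME assay on microsomes from liver (Homo sapiens) for metabolic stability, tested at 2.5 uM; a higher number here means faster removal of the compound, a lower number slower removal. Compound 1 `O=S(=O)(c1cc(Cl)cc(Cl)c1)c1cnc2cc(F)ccc2c1-c1ccccc1F` gives 0.93 mL/min. Compound 2 `O=S(=O)(c1cc(Cl)cc(Cl)c1)c1cnc2cc(F)ccc2c1-c1ccc(F)cc1` gives 0.18 mL/min. Compound 3 `O=S(=O)(c1ccc(F)c(F)c1)c1cnc2c(F)cccc2c1-c1ccc(F)cc1` gives 0.78 mL/min, which lies within the scatter of compound 1 and beyond the scatter from compound 2. Among the measured compounds shown here, the change 2-fluorophenyl in place of 4-fluorophenyl on an aromatic carbon is the single difference between compound 2 and compound 1, and it makes a 5.2-fold higher number from compound 2 to compound 1 (0.71 log units; beyond the scatter). The difference between the cores of compound 2 and compound 3 is not broken down here. Compound 4 `O=S(=O)(c1ccc(F)c(F)c1)c1cnc2c(F)cccc2c1-c1ccccc1F` is not yet measured; it differs from compound 3 by 2-fluorophenyl in place of 4-fluorophenyl on an aromatic carbon, the same change at the same place. Because the change made a 5.2-fold higher number from compound 2 to compound 1 (0.71 log units; beyond the scatter) on the other core, a step of similar direction is expected from compound 3 to compound 4, tentatively a 3.2-fold higher number from compound 3 to compound 4 (0.51 log units; beyond the scatter). On one precedent only, compound 4 is estimated at 2.5 mL/min, plausibly between 1 mL/min and 6 mL/min.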

Compound 4, intrinsic clearance in a liver preparation (reported as CLH), per the amount of preparation that the assay uses: 1.39 mL/min
For compound 4 the middle estimate is 1.8-fold (0.25 log units) above the measured one; the range from low to high includes it.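

In this assay, 2-fluorophenyl in place of 4-fluorophenyl gives a 1.8-fold higher number from compound 3 to compound 4 (0.25 log units; within the scatter), a step that does not stand clear of the scatter on this core. The size of the change does not carry over unchanged from one core to the other: the same change on two cores in this assay, a 5.2-fold higher number (0.71 log units; beyond the scatter) from compound 2 to compound 1 and a 1.8-fold higher number (0.25 log units; within the scatter) from compound 3 to compound 4, 2.9-fold (0.46 log units) apart, beyond the scatter of two such steps. With a single pair on each core, this does not show what sets the size of the step, nor how the change would behave on a further core.

From the compounds shown here alone, the two cores differ in more than one place, so the part played by each difference stays open. Only fluorophenyl groups stand at this place, which leaves open how a phenyl bearing a methoxy group, a nitrile or an amine would behave on either core.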